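A few compounds are considered here, and "the series" means these few. Any claim that something is new, unique, unknown or untested is made for them only; others in the source may bear on it.

Two compounds of the series carry numbers in an assay on isolated protein for inhibition of seed linoleate 13S-lipoxygenase-1 (Glycine max), tested at 0.1 mM; a lower number here means less inhibition, a higher number more inhibition at the concentration tested (going by the name of the read-out). Compound 1 `Cn1c(=O)c(C(=O)NCCN)c(O)c2ccccc21` gives 99.5%. Compound 2 `NCCNC(=O)c1c(O)c2ccccc2n(-c2ccccc2)c1=O` gives 82.3%. Going by the values given here, the one measured step, a number 17.2 percentage points lower from compound 1 to compound 2 (beyond the scatter), is phenyl in place of methyl on an aromatic nitrogen. Compound 2 therefore stands lowest of the two numbers; its nearest neighbour, compound 1, lies higher by that step, beyond the scatter.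

Compound 3 `NCCCCCCNC(=O)c1c(O)c2ccccc2n(-c2ccccc2)c1=O` has not yet been measured in this assay. It differs from compound 2 by 4-aminobutyl in place of amino on a saturated chain carbon, two bonds along the chain from an amide-type nitrogen. Among the compounds with values here, no measured step concerns a change of this kind: the single known step alters the group on an aromatic nitrogen, and the saturated chain carrying the amino group has not been varied among the measured compounds. The numbers give no direction for a longer chain, so the expectation is a step of a number 2.3 percentage points lower from compound 2 to compound 3 (within the scatter), not beyond the scatter. Going by these compounds, compound 3 is estimated at 80%, with a range from 55% to 97%, the width reflecting that this change is untested.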

Compound 3, a percentage reported as inhibition, at one concentration (the size of the read-out at that concentration, not a potency): 17.6%
Compound 3: the middle estimate sits 62.4 percentage points above what was measured; measured number below the stated range.
By their numbers in this assay, from the lowest: compound 3; then compound 2; then compound 1.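

In this assay, the chain carrying the terminal amine now proves to be a sensitive site: 4-aminobutyl in place of amino, on a saturated chain carbon, two bonds along the chain from an amide-type nitrogen, gives a number 64.7 percentage points lower from compound 2 to compound 3 (beyond the scatter). Going by these compounds alone, this step is large, whereas the only earlier change, phenyl in place of methyl on an aromatic nitrogen, gave a modest one, a number 17.2 percentage points lower from compound 1 to compound 2 (beyond the scatter). The leaving and entering groups have the same hydrogen-bond donor and acceptor counts and no net charge, so in this pair the loss accompanies chain extension, but no available evidence accounts for it.

Going by these compounds, it remains open whether the loss builds gradually or appears abruptly between 2-aminoethyl and 6-aminohexyl, which a 3-aminopropyl or 4-aminobutyl chain would help to resolve, and whether a longer chain has the same effect when methyl replaces phenyl on the aromatic nitrogen. The role of the terminal amine at the longer length is also unresolved, and a plain hexyl chain or a chain ending in a carboxylic acid would test it.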